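Solubility at low pH: amide for alcohol on a shared core

This account rests on a few compounds, and the source may have more. Where it says the series, first, only, none or still open, it means among the compounds named here.

Measured so far:
compound 1 `Cc1cc(/C=C/C#N)cc(C)c1Oc1cc(Nc2ccc(C#N)cc2)c(N)cc1CO` — 20.9 ug/mL
compound 2 `Cc1cc(CCC#N)cc(C)c1Oc1cc(Nc2ccc(C#N)cc2)c(N)cc1CO` — 89.8 ug/mL
compound 3 `Cc1cc(C#N)cc(C)c1Oc1cc(Nc2ccc(C#N)cc2)c(N)cc1C(F)(F)F` — 0.96 ug/mL

In a physicochemical assay for solubility, with a stated time of 4 h, at pH 2.0 (on this read-out higher numbers stand for higher solubility and lower numbers for lower solubility), compound 1 stands second highest of the three, with compound 2 nearest and compound 3 furthest. Within the data shown here, the one single-point step measured, a 4.3-fold higher number from compound 1 to compound 2 (0.63 log units; beyond the scatter), concerns a different part of the molecule and does not involve the group that changes here. Compound 4 `CNC(=O)c1cc(N)c(Nc2ccc(C#N)cc2)cc1Oc1c(C)cc(/C=C/C#N)cc1C` differs from compound 1 as follows: methylcarbamoyl in place of hydroxymethyl on an aromatic carbon. Among the measured compounds shown here, no measured pair reports this exchange, and compound 3 differs from compound 1 in two places, so its value gives no step. With nothing bearing directly on the change, compound 4 is expected to stay close to compound 1, with a 1.4-fold lower number from compound 1 to compound 4 (0.14 log units; within the scatter) likely within the scatter, at an estimated 15 ug/mL (range 4 ug/mL to 55 ug/mL).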

Compound 4, solubility: 8.63 ug/mL
Compound 4: middle estimate off by 1.7-fold (0.24 log units), on the high side, and the stated range covers the measured number.
By their numbers in this assay, from the lowest: compound 3; then compound 4; then compound 1; then compound 2.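

In this assay, methylcarbamoyl in place of hydroxymethyl on this aromatic carbon, para to the (4-cyanophenyl)amino group, gives a 2.4-fold lower number from compound 1 to compound 4 (0.38 log units; beyond the scatter) on the core of compound 1. Among these compounds, this is the first reading at this position, and it shows that the position responds to this exchange, though the step is modest. Nothing at hand gives a reason for the step.

On these data alone, whether a primary amide, a carboxylic acid or an aminomethyl group here would move the number further remains open. So does whether the exchange would give a step of similar size with the 2-cyanoethyl group of compound 2.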